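The compounds below may be only part of what the source reports. "The series", "measured", "known", "first", "only" and "open" are said of these compounds alone.

Series notes. Compound 1 `O=c1c(CSC(=S)N2CCCC2)coc2ccccc12` and compound 2 `Cc1ccc2c(=O)c(CSC(=S)N3CCCC3)coc2c1` carry a pyrrolidin-1-yl group on the thiocarbonyl carbon, whereas compound 3 `O=c1c(CSC(=S)N2CCCCC2)coc2cc(Cl)ccc12` carries piperidin-1-yl together with a chlorine on the shared core. In a functional assay on HEp-2 cells (Homo sapiens) for antiproliferative activity, read by MTT assay, with a stated time of 72 h (a lower number here means a stronger inhibitor, a higher number a weaker inhibitor), compound 1 gives 3600 nM, compound 2 gives 3600 nM and compound 3 gives 280 nM, the lowest number of the three and beyond the scatter from both of the others. Going by the values given here, the only single-point step so far, no change at the digits printed from compound 1 to compound 2 (within the scatter), does not touch the thiocarbonyl substituent. Compound 4 `O=c1c(CSC(=S)N2CCCC2)coc2cc(Cl)ccc12` keeps the chlorine of compound 3 and differs by pyrrolidin-1-yl in place of piperidin-1-yl on a thiocarbonyl carbon. Among the compounds with values here, no measured step isolates this change; compounds 1 and 3 differ in two places, so their values alone cannot assign it. A moderate shift toward a higher number is expected, a 2.5-fold higher number from compound 3 to compound 4 (0.40 log units; beyond the scatter). Compound 4 is therefore estimated at 700 nM, within 250 nM to 2500 nM.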

Compound 4, half-maximal inhibitory concentration: 2100 nM
Estimate against measurement, compound 4: 3.0-fold (0.48 log units) below; the measured number falls inside the stated range.
By their numbers in this assay, from the lowest: compound 3; then compounds 4, 1 and 2 (each within the scatter of the next).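

In this assay, the thiocarbonyl substituent now has a step of its own: with the chlorine held, pyrrolidin-1-yl in place of piperidin-1-yl on a thiocarbonyl carbon gives a clear loss (a 7.5-fold higher number from compound 3 to compound 4 (0.88 log units; beyond the scatter)). With pyrrolidin-1-yl held, the substituent on the aromatic carbon separates nothing, for chloro in place of hydrogen (a 1.7-fold lower number from compound 1 to compound 4 (0.23 log units; within the scatter)) or chloro in place of methyl (a 1.7-fold lower number from compound 2 to compound 4 (0.23 log units; within the scatter)). Within these compounds, the thiocarbonyl substituent is therefore the only single change that moves the number beyond the scatter.

As far as these compounds go, whether piperidin-1-yl keeps this edge without the chlorine, and where morpholin-4-yl or diethylamino on a thiocarbonyl carbon would fall, stay open. No evidence at hand bears on the origin of the step.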